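The source may hold more compounds than are shown below. What is called first, only, known or untested is meant among the compounds shown, and "the series" means these compounds.

Of the compounds shown here, three of one shared core have been measured in a functional assay on BMMC cells (Mus musculus, strain C57BL/6) for inhibition, with stated times of 5 days and 48 h; on this read-out lower numbers stand for stronger inhibition and higher numbers for weaker inhibition. Compound 1 `C=C1CC[C@@H]2[C@](C)(CO)[C@H](O)CC[C@@]2(C)[C@@H]1CCC1C(=O)OC[C@H]1O` carries a hydroxymethyl group where the other two carry a benzylamine chain. In this assay compound 1 gives only a limit of the assay, > 30000 nM. Compound 2 `C=C1CC[C@@H]2[C@](C)(CNCc3ccc(OC)cc3)[C@H](O)CC[C@@]2(C)[C@@H]1/C=C/C1=CCOC1=O` gives 750 nM. Compound 3 `C=C1CC[C@@H]2[C@](C)(CNCc3cccc(OC)c3)[C@H](O)CC[C@@]2(C)[C@@H]1/C=C/C1=CCOC1=O` gives 780 nM. Compound 3 and compound 2 thus stand together, the difference between them being a 1.0-fold higher number from compound 2 to compound 3 (0.02 log units; within the scatter). The remaining value, that of compound 1, is a limit and not a number.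

Compound 4 `C=C1CC[C@@H]2[C@](C)(CNCc3ccc(F)cc3)[C@H](O)CC[C@@]2(C)[C@@H]1/C=C/C1=CCOC1=O` is not yet measured. It differs from compound 3 in one place: 4-fluorophenyl in place of 3-methoxyphenyl on a saturated chain carbon bound to an amine nitrogen. Within the data shown here, the only measured step that bears on a change at this place is that from compound 2 to compound 3, where 3-methoxyphenyl replaced 4-methoxyphenyl and gave a 1.0-fold higher number from compound 2 to compound 3 (0.02 log units; within the scatter), within the scatter. On that basis no step beyond the scatter is expected, a 1.0-fold higher number from compound 3 to compound 4 (0.01 log units; within the scatter). Compound 4 is therefore estimated at 800 nM, expected to lie between 350 nM and 2000 nM.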

Compound 4, half-maximal inhibitory concentration: 350 nM
Estimate against measurement, compound 4: 2.3-fold (0.36 log units) above, and the stated range covers the measured number.
By their numbers in this assay, from the lowest: compound 4; then compounds 2 and 3 (each within the scatter of the next). At a limit, above all of these: compound 1.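

In this assay, among these compounds, the aromatic ring on the benzylamine chain had so far given no readable change: moving the methoxy group gave only a 1.0-fold higher number from compound 2 to compound 3 (0.02 log units; within the scatter). Changing the group itself does register, since 4-fluorophenyl in place of 3-methoxyphenyl gives a 2.2-fold lower number from compound 3 to compound 4 (0.35 log units; beyond the scatter), and fluoro in place of methoxy on an aromatic carbon gives a 2.1-fold lower number from compound 2 to compound 4 (0.33 log units; beyond the scatter), both modest but beyond the scatter. Nothing measured here gives a reason for these two steps.

The compounds shown leave open whether the lower number comes from the fluoro group arriving or the methoxy group leaving, and an unsubstituted phenyl, 3-fluorophenyl or 4-chlorophenyl would help to separate the two. They also leave open what a longer chain between the amine nitrogen and the ring would do.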